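Swapping a Methoxycarbonyl for Pyridin-4-yl: Expected Potency

The compounds below may be only part of what the source reports. "The series", "measured", "known", "first", "only" and "open" are said of these compounds alone.

Compound 1 `COC(=O)[C@H]1C[C@@H](c2coc3ccccc3c2=O)N(c2ccccc2)O1` was examined in a functional assay on Caco-2 cells (Homo sapiens) for inhibition, read by sulforhodamine B assay, with a stated time of 48 h; a higher number here means a weaker inhibitor, a lower number a stronger inhibitor. In this assay compound 1 gives only a limit, > 60000 nM, so its true potency is not resolved by the measurement. Compound 2 `CCO[C@H]1C[C@@H](c2coc3ccc(C)cc3c2=O)N(c2ccccc2)O1` differs from compound 1 in several places. In this assay compound 2 gives 31000 nM. Of the two measured values, one is a number and the other a limit: the limit of > 60000 nM in this assay, at which 1 of the 2 values shown sits. Among the measured compounds shown here, no step between measured compounds that differ in a single place is available, so nothing shows how much a change at this position moves potency.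

The unmeasured compound 3 `O=c1c([C@@H]2C[C@H](c3ccncc3)ON2c2ccccc2)coc2ccccc12` carries the change (pyridin-4-yl in place of methoxycarbonyl on a saturated ring carbon). The incoming group brings one six-membered aromatic ring with 1 hetero atom and a single hydrogen-bond acceptor where the outgoing group had two acceptors and no ring. Given that compound 1 sits at a limit in this assay, the step of an at least 1.3-fold lower number from compound 1 to compound 3 (0.12 log units; that floor lies within the scatter) is expected to be modest and most likely within the scatter. Compound 3 is therefore estimated at 45000 nM, with a plausible range from 12000 nM to 120000 nM.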

Compound 3, half-maximal inhibitory concentration: 37000 nM
Estimate against measurement, compound 3: 1.2-fold (0.09 log units) above; the range from low to high includes it.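

Pyridin-4-yl in place of methoxycarbonyl on this saturated ring carbon of the shared core gives the first step at this position in this assay, namely an at least 1.6-fold lower number from compound 1 to compound 3 (0.20 log units; that floor lies within the scatter). With pyridin-4-yl at this position, compound 3 gives a resolved number, 37000 nM, so the change leads to a reading the assay can state as a value. The step is still only a floor, and that floor does not clear the usual scatter, so the data do not show that the change moves potency by any defined amount, because compound 1 stands at a limit rather than at a number: the limit of > 60000 nM in this assay, at which 1 of the 3 values shown sits.

As far as these compounds go, how large the true step is remains open, and so does whether it comes from the aromatic ring itself or from the ring nitrogen of pyridin-4-yl, since this single replacement cannot separate the two. A phenyl group on the same saturated ring carbon would bear on that question, and a carboxylic acid or an amine there would show how far the reading of compound 3 holds for groups of another kind.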